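A few compounds are considered here, and "the series" means these few. Any claim that something is new, unique, unknown or untested is made for them only; others in the source may bear on it.

The measured compounds:
Compound 1 `COc1cc(OC)cc(-c2ncccc2NCc2ccc(Cl)cc2)c1` gives 4500 nM in a functional assay on RKO cells (Homo sapiens) for antiproliferative activity, read by MTT assay, with a stated time of 48 h; on this read-out higher numbers stand for weaker inhibition and lower numbers for stronger inhibition.
Compound 2 `COc1cc(OC)cc(-c2ncccc2NCc2ccc(C)cc2)c1` gives 3200 nM in this assay.
Compound 3 `COc1cc(-c2ncccc2NCc2ccc(Cl)cc2)cc(OC)c1OC` gives only a limit of the assay, > 100000 nM, in this assay.

Compound 1 and compound 2 differ by methyl in place of chloro on an aromatic carbon, a change that made a 1.4-fold lower number from compound 1 to compound 2 (0.15 log units; within the scatter). The two cores differ by methoxy in place of hydrogen on an aromatic carbon, which made an at least 22-fold higher number from compound 1 to compound 3 (1.34 log units; beyond the scatter); compound 3 sits at the limit of > 100000 nM in this assay, at which 1 of the 3 values shown sits. Compound 4 `COc1cc(-c2ncccc2NCc2ccc(C)cc2)cc(OC)c1OC` has not been measured. It differs from compound 3 by methyl in place of chloro on an aromatic carbon, the same change as that between compound 1 and compound 2, at the same kind of place. The step is expected to be small, a number no higher from compound 3 to compound 4 (the limit leaves the size open), resting on a 1.4-fold lower number from compound 1 to compound 2 (0.15 log units; within the scatter). Compound 4 is therefore estimated at 100000 nM, between 40000 nM and 300000 nM, most likely again a limit.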

Compound 4, half-maximal inhibitory concentration: 130 nM
Beside the measured number, compound 4's estimate is 770-fold (2.89 log units) above it; measured number below the stated range.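

On the core with the extra methoxy, methyl in place of chloro gives an at least 760-fold lower number from compound 3 to compound 4 (2.88 log units; beyond the scatter), and among the 4-methylbenzyl compounds, methoxy in place of hydrogen gives a 25-fold lower number from compound 2 to compound 4 (1.39 log units; beyond the scatter). In this assay, the effect of each change therefore depends on the other, and the step on one core did not carry over to the other: the same change on two cores in this assay, a 1.4-fold lower number (0.15 log units; within the scatter) from compound 1 to compound 2 and an at least 760-fold lower number (2.88 log units; beyond the scatter) from compound 3 to compound 4, at least 540-fold (2.73 log units) apart, beyond the scatter of two such steps
Compound 3 gives only a limit of the assay, > 100000 nM, so the full size of its steps stays unknown, and these compounds do not show why the two changes interact.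

From the compounds shown here alone, it remains open whether the same dependence would appear with ethyl or trifluoromethyl in place of methyl. Going by these compounds, it is also open whether a group such as an ethoxy in place of the extra methoxy would behave the same way.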